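A few compounds are considered here, and "the series" means these few. Any claim that something is new, unique, unknown or untested is made for them only; others in the source may bear on it.

In an ADME assay on MRC5 cells (Homo sapiens) for inhibition, read by MTT assay, with a stated time of 72 h (a lower number here means a stronger inhibitor, a higher number a weaker inhibitor), compound 1 `CCCCCCOC(=O)OCCc1ccc(O)c(O)c1` gives 11200 nM and compound 2 `CCCCCCCCOC(=O)OCCc1ccc(O)c(O)c1` gives 37900 nM as the higher of the two numbers, which makes it the weaker inhibitor of the pair. Within the data shown here, the only measured step that bears on what follows is a 3.4-fold higher number from compound 1 to compound 2 (0.53 log units; beyond the scatter) for ethyl in place of hydrogen on a saturated chain carbon, six bonds along the chain from an oxygen next to a carbonyl group. Compound 3 `CCCCCCCCCOC(=O)OCCc1ccc(O)c(O)c1` differs from compound 2 by methyl in place of hydrogen on a saturated chain carbon, eight bonds along the chain from an oxygen next to a carbonyl group on the same chain. One step is thin evidence and cannot show whether the trend continues. Judged against a 3.4-fold higher number from compound 1 to compound 2 (0.53 log units; beyond the scatter) as the sole guide, a smaller rise in this assay is expected for this methyl, in the same direction. The estimated change is a 1.6-fold higher number from compound 2 to compound 3 (0.20 log units; within the scatter) and may prove hard to tell from the scatter. For compound 3 the expected value is 60000 nM with 25000 nM to 140000 nM as its range.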

Compound 3, half-maximal inhibitory concentration: 15900 nM
Estimate against measurement, compound 3: 3.8-fold (0.58 log units) above; the measured number lies below the stated range.
By their numbers in this assay, from the lowest: compounds 1 and 3 (each within the scatter of the next); then compound 2.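

In this assay the methyl added at this place, eight bonds along the chain from an oxygen next to a carbonyl group, does not continue the earlier rise: it reverses it, with a 2.4-fold lower number from compound 2 to compound 3 (0.38 log units; beyond the scatter) and so a stronger inhibitor in compound 3 than in compound 2. Propyl in place of hydrogen gives a 1.4-fold higher number from compound 1 to compound 3 (0.15 log units; within the scatter) and these two compounds cannot be told apart, which leaves compound 2 alone with the highest number and goes against any steady rise as the chain grows. Nothing measured here accounts for this turn.

Three compounds cannot show whether a longer chain would stay close to compound 3 or shift the number again. Going by these compounds, how an amine or a carboxylic acid on this chain would read also remains open.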